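The compounds below may be only part of what the source reports. "The series", "measured", "known", "first", "only" and "open" are said of these compounds alone.

Measured compounds in a functional assay on MIA PaCa-2 cells (Homo sapiens) for inhibition, read by MTT assay, with a stated time of 72 h; on this read-out lower numbers stand for stronger inhibition of growth and higher numbers for weaker inhibition of growth:

Compound 1, `O=S(=O)(NCCCNCc1ccc(Cl)c(Cl)c1)c1cc(C(F)(F)F)cc(C(F)(F)F)c1`, gives 2700 nM.
Compound 2, `O=S(=O)(NCCCNCc1ccc(C(F)(F)F)cc1)c1cc(C(F)(F)F)cc(C(F)(F)F)c1`, gives 2500 nM.
Compound 3, `O=S(=O)(NCCCNCc1ccccc1)c1cc(C(F)(F)F)cc(C(F)(F)F)c1`, gives 11000 nM.

Compound 3 stands at the highest of the three numbers in this assay, meaning the weakest inhibition of growth among them: its nearest neighbour is compound 1, and compound 2 lies a little further off. Compound 4, `O=S(=O)(NCCCNCc1ccc(Cl)cc1)c1cc(C(F)(F)F)cc(C(F)(F)F)c1`, is the next compound. It differs from compound 3 by chloro in place of hydrogen on an aromatic carbon, so the benzyl group of compound 3 becomes a 4-chlorobenzyl group.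

Among the compounds with values here, two measured steps bear on this. Removing a trifluoromethyl from that same ring gave a 4.4-fold higher number from compound 2 to compound 3 (0.64 log units; beyond the scatter), and going from 3,4-dichlorophenyl to bare phenyl gave a 4.1-fold higher number from compound 1 to compound 3 (0.61 log units; beyond the scatter). Both say that a substituent on this ring lowers the number by a modest amount, while a 1.1-fold lower number from compound 1 to compound 2 (0.03 log units; within the scatter) shows that swapping one such substituent for another changes little. A single chloro is therefore expected to move compound 4 back toward those values, with an estimated 3.4-fold lower number from compound 3 to compound 4 (0.54 log units; beyond the scatter). Compound 4 is estimated at 3200 nM, with a range from 1500 nM to 7000 nM.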

Compound 4, concentration for 50% growth inhibition: 2800 nM
Compound 4: the middle estimate sits 1.1-fold (0.06 log units) above what was measured; the measured number falls inside the stated range.
By their numbers in this assay, from the lowest: compounds 2, 1 and 4 (each within the scatter of the next); then compound 3.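

In this assay, a single chloro at this place, para to a large group, is enough for a modest step (a 3.9-fold lower number from compound 3 to compound 4 (0.59 log units; beyond the scatter)), so the earlier gains from substituting the ring do not need a second chloro or a trifluoromethyl. Compound 4 cannot be told apart from its two neighbours: the second chloro of compound 1 makes no measurable difference (a 1.0-fold higher number from compound 1 to compound 4 (0.02 log units; within the scatter)), and neither does trifluoromethyl in place of chloro (a 1.1-fold higher number from compound 2 to compound 4 (0.05 log units; within the scatter)). Nothing measured here explains why these substituents behave alike. Still open, going by these compounds, is whether a methoxy, a nitrile or an amine on this aromatic carbon would give a step of similar size. Also open, on these data alone, is whether the chloro step would hold with a longer chain between the two nitrogens of the shared core.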